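This account rests on a few compounds, and the source may have more. Where it says the series, first, only, none or still open, it means among the compounds named here.

Compound 1 `Cn1cc(/C=C/C(=O)c2ccccc2)cc1/C=C/C(=O)NO` is the parent of this small set. In an assay on isolated protein for inhibition of histone deacetylase HD1B (Zea mays) (on this read-out higher numbers stand for weaker inhibition and lower numbers for stronger inhibition), compound 1 gives 260 nM. Compound 2 `Cn1cc(/C=C/C(=O)c2ccccc2Cl)cc1/C=C/C(=O)NO` carries a 2-chlorophenyl on the carbonyl carbon, and in this assay compound 2 gives 1600 nM; the step of a 6.2-fold higher number from compound 1 to compound 2 (0.79 log units; beyond the scatter) is modest. Compound 3 `Cn1cc(/C=C/C(=O)c2cccc(Cl)c2)cc1/C=C/C(=O)NO` carries a 3-chlorophenyl on that carbonyl carbon, and in this assay compound 3 gives 31400 nM. Compound 3 therefore stands highest of the three, with the steps of a 120-fold higher number from compound 1 to compound 3 (2.08 log units; beyond the scatter) and a 20-fold higher number from compound 2 to compound 3 (1.29 log units; beyond the scatter) both large and both beyond the scatter.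

Compound 4 `Cn1cc(/C=C/C(=O)c2ccc(Cl)cc2)cc1/C=C/C(=O)NO` differs from compound 3 by 4-chlorophenyl in place of 3-chlorophenyl on a carbonyl carbon. Among the measured compounds shown here, two measured steps bear on this change. The step of a 20-fold higher number from compound 2 to compound 3 (1.29 log units; beyond the scatter) shows that exchanging one chlorophenyl for another can shift the number a great deal, and the step of a 6.2-fold higher number from compound 1 to compound 2 (0.79 log units; beyond the scatter) shows that one chlorophenyl costs far less against the parent than the other. For the measured compounds named here, no measured compound carries a 4-chlorophenyl, so the step of a 5.2-fold lower number from compound 3 to compound 4 (0.72 log units; beyond the scatter) is expected with little confidence as to its size. Compound 3 already stands at the high end of the set, and the number for compound 4 is expected to come down from it rather than rise further. Compound 4 is estimated to give 6000 nM in this assay, within a range from 1000 nM to 40000 nM.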

Compound 4, half-maximal inhibitory concentration: 29400 nM
Estimate against measurement, compound 4: 4.9-fold (0.69 log units) below, and the stated range covers the measured number.
By their numbers in this assay, from the lowest: compound 1; then compound 2; then compounds 4 and 3 (each within the scatter of the next).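

In this assay, 4-chlorophenyl in place of 3-chlorophenyl on the carbonyl carbon gives a 1.1-fold lower number from compound 3 to compound 4 (0.03 log units; within the scatter), so this assay does not separate these two groups, although the earlier compounds had shown that exchanging one chlorophenyl for another can matter a great deal. The 2-chlorophenyl now stands alone among the three: replacing it with 4-chlorophenyl gives an 18-fold higher number from compound 2 to compound 4 (1.26 log units; beyond the scatter), a step much like a 20-fold higher number from compound 2 to compound 3 (1.29 log units; beyond the scatter), and chloro in place of hydrogen gives a 110-fold higher number from compound 1 to compound 4 (2.05 log units; beyond the scatter), against only a 6.2-fold higher number from compound 1 to compound 2 (0.79 log units; beyond the scatter) for the 2-chlorophenyl compound. Nothing among the data shown accounts for this split among the three chlorophenyl groups.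

The compounds shown leave open whether the same split would appear with a group other than chloro on this phenyl, such as fluoro, methoxy, an amine or a carboxylic acid. They also leave open whether any substituted phenyl on the carbonyl carbon can match or improve on the unsubstituted parent, since all three chlorophenyl compounds give higher numbers than compound 1.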